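The compounds below may be only part of what the source reports. "The series", "measured", "known", "first", "only" and "open" are said of these compounds alone.

Of the compounds shown here, two built on one shared core have been measured so far. Within the data shown here, compound 1 `Fc1cc(Br)ccc1Nc1nc2nonc2nc1Nc1ccc(Br)cc1F` and compound 2 `Fc1ccccc1Nc1nc2nonc2nc1NC1CCCCC1` differ at more than one place, so no single step links them. In an assay on mitochondria from L6 cells (Rattus norvegicus) for activation, with a stated time of 90 min (a higher number here means that more compound is needed for the effect, a lower number that less compound is needed), compound 2 gives 13400 nM. Compound 1 returned in this assay only a limit, < 3000 nM. Compound 2 therefore stands as the sole measured number shown, beside one further value that is a limit (the limit of < 3000 nM in this assay, at which 1 of the 2 values shown sits). Compound 3 `CCOc1ccc(Nc2nc3nonc3nc2Nc2ccccc2F)cc1` has not yet been measured. It differs from compound 2 in one place (4-ethoxyphenyl in place of cyclohexyl on a nitrogen on an aromatic ring), that is, 4-ethoxyphenyl in place of cyclohexyl on a nitrogen on an aromatic ring, so a six-membered aromatic ring enters where a six-membered non-aromatic ring leaves. Among the measured compounds shown here, no step between measured compounds is available to size this change, and the two measured values can only be read as they stand. The step is nonetheless expected to lower the number beyond the scatter, by a 3.8-fold lower number from compound 2 to compound 3 (0.58 log units; beyond the scatter). Compound 3 is accordingly estimated at 3500 nM, with a range from 900 nM to 14000 nM.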

Compound 3, half-maximal effective concentration: 3800 nM
Compound 3: middle estimate off by 1.1-fold (0.04 log units), on the low side, within the range that was stated.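

Before this, no two measured compounds differed in one place, so the substituent on this nitrogen on an aromatic ring had no step attached to it. In this assay, 4-ethoxyphenyl in place of cyclohexyl now gives a 3.5-fold lower number from compound 2 to compound 3 (0.55 log units; beyond the scatter) and so shows that this position responds to a change of group, modestly but measurably, and that the larger aromatic group does not raise the number. The step changes several things at once, as a six-membered aromatic ring replaces a non-aromatic one and a hydrogen-bond acceptor enters with the ethoxy oxygen, so this single pair cannot say which of these carries the shift.

Still open, as far as these compounds go, is whether plain phenyl without the ethoxy, or an amine or a carboxylic acid at the same place, would move the number in the same direction. Compound 1 adds no further number for this question, since its reading is only a limit: the limit of < 3000 nM in this assay, at which 1 of the 3 values shown sits.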